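From Cyclobutyl to Neopentyl on the Shared Core

This account rests on a few compounds, and the source may have more. Where it says the series, first, only, none or still open, it means among the compounds named here.

Compound 2 `Cn1c(C2CCC2)nc2ccc(-n3ccc(OCc4ccc(F)cc4)cc3=O)cc21` stands as the weaker of the two measured compounds: in an assay on CHO cells for displacement of a labelled ligand from melanin-concentrating hormone receptor 1 (Homo sapiens), read by scintillation counting, with a stated time of 1 h (a lower number here means a stronger inhibitor, a higher number a weaker inhibitor), compound 2 gives 240 nM, whereas compound 1 `CCc1nc2ccc(-n3ccc(OCc4ccc(F)cc4)cc3=O)cc2n1C` gives 48 nM in this assay. Within the data shown here, the single measured step, a 5.0-fold higher number from compound 1 to compound 2 (0.70 log units; beyond the scatter), is the only guide available. Compound 3 `Cn1c(CC(C)(C)C)nc2ccc(-n3ccc(OCc4ccc(F)cc4)cc3=O)cc21` changes the same group once more: neopentyl in place of cyclobutyl on an aromatic carbon. The step from compound 1 to compound 2 exchanged ethyl for cyclobutyl and moved the number upward; the change to compound 3 exchanges that cyclobutyl for neopentyl. Among the measured compounds shown here, with only one step known, and that step involving a ring rather than a branched chain, the expectation for compound 3 is held near compound 2, with a slight lean toward a higher number or no step beyond the scatter, rather than a return toward compound 1. Compound 3 is therefore expected to give about 300 nM in this assay, within a range of 100 nM to 1000 nM, which amounts to an expected 1.3-fold higher number from compound 2 to compound 3 (0.10 log units; within the scatter).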

Compound 3, half-maximal inhibitory concentration: > 1000 nM
Compound 3: a limit, no number; the forecaster's own chance of this, stated with the estimate: 3%; middle value at least 3.3-fold (0.52 log units) from the limit.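

In this assay compound 3 gives > 1000 nM, which is a limit of the assay and not a number, so the size of its steps is bounded on one side only: the limit of > 1000 nM in this assay, at which 1 of the 3 values shown sits.

The result shows that the loss at this aromatic carbon between two ring nitrogen atoms does not depend on the four-membered ring, since the open neopentyl chain brings an at least 4.1-fold higher number from compound 2 to compound 3 (0.61 log units; beyond the scatter). Set against the ethyl group, the same position shows an at least 20-fold higher number from compound 1 to compound 3 (1.31 log units; beyond the scatter), so among these three compounds the number rises from ethyl through cyclobutyl to neopentyl, and none of them goes against that order.

With only these three groups, the compounds leave open whether the rise follows branching or simply the size of the group, which an unbranched propyl or butyl chain at this carbon would help to separate. They also leave open how a plain methyl, or a chain ending in an amine or a carboxylic acid, would compare with the ethyl group of compound 1.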